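The source may hold more compounds than are shown below. What is called first, only, known or untested is meant among the compounds shown, and "the series" means these compounds.

In a functional assay (muscle tissue) with Felis catus as the target (on this read-out higher numbers stand for an effect only at larger amounts of compound and lower numbers for an effect already at smaller amounts), compound 1 `CCNc1nc(C)nc(O)c1[N+](=O)[O-]` gives 25000 nM and compound 2 `Cc1nc(O)c([N+](=O)[O-])c(NCc2cccnc2)n1` gives 5300 nM as the lower of the two numbers. Compound 2 therefore shows its effect at the smaller amount of the pair. Compound 3 `Cc1nc(O)c(Br)c(NCc2cccnc2)n1` has bromo in place of nitro on an aromatic carbon and keeps the rest of compound 2 unchanged.

Among the compounds with values here, the only measured step is a 4.7-fold lower number from compound 1 to compound 2 (0.67 log units; beyond the scatter) with pyridin-3-yl in place of methyl on a saturated chain carbon bound to a nitrogen on an aromatic ring. That modest step lies at a different place in the structure. Within the data shown here, no measured pair shows what replacing nitro with bromo does, and the data offer no direction for this change. The central expectation in this assay is therefore no step beyond the scatter, with a wide margin on either side.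

The step expected at the centre of the estimate is a 1.1-fold higher number from compound 2 to compound 3 (0.05 log units; within the scatter) and it remains uncertain. For compound 3 the estimated value is 6000 nM with an expected range from 1500 nM to 25000 nM around it.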

Compound 3, half-maximal effective concentration: 3900 nM
The estimate for compound 3 lay 1.5-fold (0.19 log units) above the measured number; the measured number falls inside the stated range.
By their numbers in this assay, from the lowest: compounds 3 and 2 (each within the scatter of the next); then compound 1.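

In this assay, the exchange of nitro for bromo on the aromatic carbon ortho to the hydroxy group comes out as a 1.4-fold lower number from compound 2 to compound 3 (0.13 log units; within the scatter), so the two compounds cannot be told apart on this read-out. The earlier compounds shown here said nothing about this position, and it now appears that the effect in this assay holds when a group of 3 heavy atoms with 2 hydrogen-bond acceptors gives way to a single bromine atom with no hydrogen-bond acceptors. Nothing among the accompanying data speaks to why these two different groups read alike.

A single exchange cannot show how much variety this position accepts, and a chloro, a nitrile or a methoxy group on the same carbon would show how far this holds. Among the compounds shown, bromo appears only together with the pyridin-3-yl chain of compound 3, so whether the same exchange would read alike with the chain of compound 1 remains open.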